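The source may hold more compounds than are shown below. What is called first, only, known or untested is meant among the compounds shown, and "the series" means these compounds.

Compound 3 `CN(C)CCn1cnnc1-c1cc(Oc2ccc(NC(=O)N/N=C/c3ccc(O)c(Br)c3)cc2F)ccn1` gives the lowest number of the three measured here in a functional assay on HT-29 cells (Homo sapiens) for cytotoxicity, read by MTT assay, with a stated time of 72 h; on this read-out lower numbers stand for stronger inhibition and higher numbers for weaker inhibition: compound 3 gives 450 nM. Compound 1 `CN(C)CCn1cnnc1-c1cc(Oc2ccc(NC(=O)N/N=C/c3ccc(F)cc3Cl)cc2F)ccn1` gives 510 nM, and the step of a 1.1-fold lower number from compound 1 to compound 3 (0.05 log units; within the scatter) sits within the scatter, so the two cannot be told apart. Compound 2 `CN(C)CCn1cnnc1-c1cc(Oc2ccc(NC(=O)N/N=C/c3ccc(O)c(F)c3)cc2F)ccn1` gives 3310 nM, and the step of a 7.4-fold lower number from compound 2 to compound 3 (0.87 log units; beyond the scatter) lies beyond the scatter.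

Compound 4 `CN(C)CCn1cnnc1-c1cc(Oc2ccc(NC(=O)N/N=C/c3ccc(F)cc3)cc2F)ccn1` differs from compound 3 in one place: 4-fluorophenyl in place of 3-bromo-4-hydroxyphenyl on a carbon with a double bond to nitrogen. Within the data shown here, two measured steps bear on this change. The step of a 1.1-fold lower number from compound 1 to compound 3 (0.05 log units; within the scatter) shows that swapping one halogenated ring for another left the number essentially unchanged, while a 7.4-fold lower number from compound 2 to compound 3 (0.87 log units; beyond the scatter) shows that the choice of halogen on that ring can shift the number by a modest amount. Compound 4 keeps a halogen but loses the hydroxyl and the bromo of compound 3, and the nearest measured relative is compound 1 with 510 nM. A small rise in the number is therefore expected for compound 4, a 2.0-fold higher number from compound 3 to compound 4 (0.30 log units; within the scatter), giving an estimated 900 nM within a range of 350 nM to 2500 nM in this assay .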

Compound 4, half-maximal inhibitory concentration: 1370 nM
Compound 4: the middle estimate sits 1.5-fold (0.18 log units) below what was measured; the measured number falls inside the stated range.
By their numbers in this assay, from the lowest: compounds 3 and 1 (each within the scatter of the next); then compound 4; then compound 2.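

In this assay, the bare 4-fluorophenyl ring can be told apart from the ring of compound 3, with a 3.0-fold higher number from compound 3 to compound 4 (0.48 log units; beyond the scatter), and taking away the chloro alone gives a 2.7-fold higher number from compound 1 to compound 4 (0.43 log units; beyond the scatter), so one halogen on this ring is enough to move the number. A hydroxyl on the ring does not by itself bring a lower number: a 2.4-fold lower number from compound 2 to compound 4 (0.38 log units; beyond the scatter), so compound 2 goes against the lower number seen with the hydroxyl-bearing ring of compound 3. Nothing measured here accounts for these shifts.

The compounds shown leave open how much of the step to compound 4 belongs to the bromo and how much to the hydroxyl, which a ring carrying bromo alone would separate. They also leave open how a methoxy group or an amine would read in place of that hydroxyl.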